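Replacing the chlorophenyl with a naphthyl in a triazolopyrimidine hydrazone

The compounds below may be only part of what the source reports. "The series", "measured", "known", "first", "only" and "open" are said of these compounds alone.

Compound 1 `CCCSc1nc(N/N=C/c2ccc(Cl)cc2)c2nnn(Cc3ccccc3)c2n1` was tested in a functional assay on MGC-803 cells (Homo sapiens) for antiproliferative activity, read by MTT assay, with a stated time of 72 h (on this read-out higher numbers stand for weaker inhibition and lower numbers for stronger inhibition), where it reaches only a limit of the assay at > 64000 nM. Compound 2 `CCCSc1nc(N/N=C(\C)c2ccccc2)c2nnn(Cc3ccccc3)c2n1` gives 25400 nM in this assay, and the change an at least 2.5-fold lower number from compound 1 to compound 2 (0.40 log units; beyond the scatter) shows that altering the group on the hydrazone nitrogen can move the number. Compound 3 `CCCSc1nc(N/N=C/c2ccc3ccccc3c2)c2nnn(Cc3ccccc3)c2n1` differs from compound 1 by naphthalen-2-yl in place of 4-chlorophenyl on a carbon with a double bond to nitrogen. Among the compounds with values here, only the step from compound 1 to compound 2 bears on this, and it rests on a limit (the limit of > 64000 nM in this assay, at which 1 of the 2 values shown sits), so the expectation is uncertain. Compound 3 is estimated at 30000 nM (range 8000 nM to 100000 nM), an expected change of an at least 2.1-fold lower number from compound 1 to compound 3 (0.32 log units; beyond the scatter).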

Compound 3, half-maximal inhibitory concentration: > 64000 nM
Compound 3 gave a limit, no number; the forecaster's own chance of this, stated with the estimate: 35%; at least 2.1-fold (0.32 log units) between middle value and limit.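

Compound 1 and compound 3 both give a limit of the assay rather than a number, so no step between them can be read: the limit of > 64000 nM in this assay, at which 2 of the 3 values shown sit.

The compounds shown leave open whether naphthalen-2-yl in place of 4-chlorophenyl changes the activity at all.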